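The compounds below may be only part of what the source reports. "The series", "measured", "known", "first", "only" and "open" are said of these compounds alone.

In a functional assay on C6 cells (Rattus norvegicus) for inhibition, read by sulforhodamine B assay, with a stated time of 72 h (on this read-out lower numbers stand for an effect already at smaller amounts and higher numbers for an effect only at larger amounts of compound), compound 1 (`O=C(/C=C/c1ccc([N+](=O)[O-])o1)c1ccc(N2CCNCC2)cc1`) gives 1500 nM as its reading. Compound 2 (`COc1ccc(/C=C/C(=O)c2cccc(Br)c2)cc1`) gives 22300 nM there, the higher of the two numbers, and the gap between them lies beyond the usual scatter. Among the measured compounds shown here, these two compounds do not differ in just one place, so no measured step is available as a guide. Compound 3 (`COc1ccc(/C=C/C(=O)c2cccc(I)c2)cc1`) differs from compound 2 in a single place (iodo in place of bromo on an aromatic carbon): iodo in place of bromo on an aromatic carbon, meta to a large group. In this assay no step beyond the scatter is expected for this exchange, and two values cannot settle a direction firmly. The estimated change is a 1.2-fold lower number from compound 2 to compound 3 (0.09 log units; within the scatter) and stays within the scatter. For compound 3 the expected value is 18000 nM within an estimated range from 8000 nM to 40000 nM on this read-out.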

Compound 3, half-maximal effective concentration: 14600 nM
Beside the measured number, compound 3's estimate is 1.2-fold (0.09 log units) above it; the measured number falls inside the stated range.
By their numbers in this assay, from the lowest: compound 1; then compounds 3 and 2 (each within the scatter of the next).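

In this assay, among the compounds shown here, the exchange of bromo for iodo on an aromatic carbon, meta to a large group, gives a 1.5-fold lower number from compound 2 to compound 3 (0.18 log units; within the scatter) and is the only step between compounds that differ in one place. It shows that, at this position and on this read-out, the two halogens cannot be told apart, something the earlier pair could not show, since compound 1 and compound 2 differ in more than one place. No available evidence bears on this result.

From the compounds shown here alone, what an amine, a carboxylic acid or a nitrile would give on the same aromatic carbon stays open, so the reach of this position beyond bromo and iodo is unknown. Also open, going by these compounds, is whether the same exchange would behave alike on the core of compound 1.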